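This account rests on a few compounds, and the source may have more. Where it says the series, first, only, none or still open, it means among the compounds named here.

Notes on the series. Compound 1 `OC(Cc1ccccc1)c1cccc2[nH]ncc12` gives 66000 nM in an assay for binding affinity to Indoleamine 2,3-dioxygenase 1 variant C129Y (Homo sapiens), read by spectrophotometry, with a stated time of 30 min; on this read-out higher numbers stand for weaker binding and lower numbers for tighter binding. Compound 2 `Cc1cc(C(O)Cc2ccccc2)c2cn[nH]c2c1` gives 27000 nM in this assay, and the step of a 2.4-fold lower number from compound 1 to compound 2 (0.39 log units; beyond the scatter). Compound 3 `C#Cc1cc(C(O)Cc2ccccc2)c2cn[nH]c2c1` gives 94000 nM in this assay; it holds the highest of the three numbers, with compound 1 nearest and compound 2 furthest, as the steps of a 1.4-fold higher number from compound 1 to compound 3 (0.15 log units; within the scatter) and a 3.5-fold higher number from compound 2 to compound 3 (0.54 log units; beyond the scatter) show.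

Compound 4 `OC(Cc1ccccc1)c1cc(C2CC2)cc2[nH]ncc12` differs from compound 3 as follows: cyclopropyl in place of ethynyl on an aromatic carbon. Of the measured steps, a 3.5-fold higher number from compound 2 to compound 3 (0.54 log units; beyond the scatter) and a 2.4-fold lower number from compound 1 to compound 2 (0.39 log units; beyond the scatter) bear on it most, since both involve an alkyl group on the same aromatic carbon and both point toward lower numbers for alkyl than for ethynyl or hydrogen; a 1.4-fold higher number from compound 1 to compound 3 (0.15 log units; within the scatter) stayed within the scatter. Within the data shown here, no measured step shows cyclopropyl itself. On this basis a modest step toward a lower number is expected for compound 4, of about a 3.1-fold lower number from compound 3 to compound 4 (0.50 log units; beyond the scatter). Compound 4 is therefore estimated at 30000 nM in this assay, within the range 10000 nM to 90000 nM.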

Compound 4, dissociation constant: 28000 nM
Compound 4: the middle estimate sits 1.1-fold (0.03 log units) above what was measured, and the stated range covers the measured number.
By their numbers in this assay, from the lowest: compounds 2 and 4 (each within the scatter of the next); then compounds 1 and 3 (each within the scatter of the next).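

At this carbon in this assay, the two alkyl groups cannot be told apart, with a 1.0-fold higher number from compound 2 to compound 4 (0.02 log units; within the scatter), so the three-membered ring of cyclopropyl offers no measurable gain or loss against methyl. Compared with hydrogen, cyclopropyl gives a 2.4-fold lower number from compound 1 to compound 4 (0.37 log units; beyond the scatter), and compared with ethynyl it gives a 3.4-fold lower number from compound 3 to compound 4 (0.53 log units; beyond the scatter), so a second alkyl group now repeats the separation from these two groups first seen with methyl alone. Nothing on hand gives a reason for these differences.

From the compounds shown here alone, whether a longer chain such as n-propyl, a methoxy group or an amine on this carbon would hold the number of compound 2 and compound 4 remains open. Going by these compounds, the hydroxyl and the phenyl are the same in all four compounds, so what changes there would do is also open.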